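Adding an isobutyl branch to the hydroxyethyl arm

The compounds below may be only part of what the source reports. "The series", "measured", "known", "first", "only" and "open" are said of these compounds alone.

Compound 2 `CC(O)c1cn(CCNc2nonc2/C(=N/O)Nc2ccc(F)c(Br)c2)nn1`: 53 nM
Compound 1 `CC(C)(C)c1cn(CCNc2nonc2/C(=N/O)Nc2ccc(F)c(Br)c2)nn1`: 132 nM

In an assay on isolated protein for inhibition of Indoleamine 2,3-dioxygenase 1 (Homo sapiens) (a lower number here means a stronger inhibitor, a higher number a weaker inhibitor), compound 2 gives the lower of the two numbers, with compound 1 giving 132 nM after the step of a 2.5-fold lower number from compound 1 to compound 2 (0.40 log units; beyond the scatter). Compound 3 `CC(C)CC(C)(O)c1cn(CCNc2nonc2/C(=N/O)Nc2ccc(F)c(Br)c2)nn1` keeps the hydroxyl and differs by isobutyl in place of hydrogen on a saturated chain carbon bound to an aromatic carbon, an oxygen on a saturated carbon and a saturated chain carbon. Going by the values given here, the only measured step, from a larger group without a hydroxyl to a smaller one with it, bears on this change loosely: it suggests extra carbon at this point does not help, but the hydroxyl is retained. A modest step, if any, is therefore expected, a 1.6-fold higher number from compound 2 to compound 3 (0.21 log units; within the scatter) toward a higher number. Compound 3 is estimated at 85 nM, between 30 nM and 240 nM.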

Compound 3, half-maximal inhibitory concentration: 51 nM
Compound 3: the middle estimate sits 1.7-fold (0.22 log units) above what was measured; low and high end bracket the measured number.
By their numbers in this assay, from the lowest: compounds 3 and 2 (each within the scatter of the next); then compound 1.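

In this assay the added isobutyl on the hydroxyl-bearing carbon leaves the number within the scatter (a 1.0-fold lower number from compound 2 to compound 3 (0.02 log units; within the scatter)), so this position accepts that extra carbon without a measurable change. The 1-hydroxy-1,3-dimethylbutyl group also stays beyond the scatter from tert-butyl (a 2.6-fold lower number from compound 1 to compound 3 (0.41 log units; beyond the scatter)), which shows that a large group with a hydroxyl can match the smaller 1-hydroxyethyl. From the compounds shown here alone, it remains open whether the hydroxyl itself is required, which a methyl ether or an amine at this carbon would test, and how a longer chain or a carboxylic acid would fare. No measurement offered here accounts for this result.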